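From compound 2 to compound 4: an expected half-life

The source may hold more compounds than are shown below. What is called first, only, known or untested is meant among the compounds shown, and "the series" means these compounds.

In an ADME assay on the whole organism for metabolic stability, with Rattus norvegicus as the target, at a dose of 20 mg/kg by the oral route (on this read-out higher numbers stand for a longer-lived compound and lower numbers for a shorter-lived compound), compound 2 (`Cc1c(OCCCCOc2ccc(C(=O)O)cc2)ccc(C(=O)CC(C)C)c1O`) gives 5.05 h and stands within the scatter of compound 1 (`COc1cc(C(=O)O)ccc1OCCCCOc1ccc(C(=O)CC(C)C)c(O)c1C`) at 7.85 h and of compound 3 (`COc1ccc(C(=O)O)cc1OCCCCOc1ccc(C(=O)CC(C)C)c(O)c1C`) at 9.48 h on the same read-out. Compound 4 (`Cc1c(OCCCCOc2ccc(F)c(C(=O)O)c2)ccc(C(=O)CC(C)C)c1O`) has 3-carboxy-4-fluorophenyl in place of 4-carboxyphenyl on an oxygen on a saturated carbon. Among the compounds with values here, no measured compound carries the new group. Within the data shown here, only one measured step touches the group that leaves: with hydrogen in place of methoxy on an aromatic carbon, the step was a 1.6-fold lower number from compound 1 to compound 2 (0.19 log units; within the scatter) and lay within the scatter. On that evidence, the expected step is a 1.2-fold higher number from compound 2 to compound 4 (0.07 log units; within the scatter) and no shift beyond the scatter is foreseen. Compound 4 is expected to show a half-life of 6 h with 3 h to 11 h as its range.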

Compound 4, half-life: 1.48 h
Estimate against measurement, compound 4: 4.1-fold (0.61 log units) above; measured number below the stated range.
By their numbers in this assay, from the lowest: compound 4; then compounds 2, 1 and 3 (each within the scatter of the next).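

In this assay, the step of a 3.4-fold lower number from compound 2 to compound 4 (0.53 log units; beyond the scatter) is the first shown here that lies beyond the scatter, and it falls at the aryl group on the oxygen on a saturated carbon. The half-life therefore responds to the aryl group at this place, although the step from methoxy to hydrogen on an aromatic carbon left it within the scatter. No measurement shown here accounts for this step.

The change introduces fluorine and a 3-carboxy arrangement together, and the compounds shown do not separate the two. From the compounds shown here alone, whether 3-carboxyphenyl without fluorine, or a 4-fluorophenyl group bearing a tetrazole, would behave likewise remains open.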